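Removing one methyl from a compound at the assay limit

The compounds below may be only part of what the source reports. "The series", "measured", "known", "first", "only" and "open" are said of these compounds alone.

Measured so far in an ADME assay on BaF3 cells (Mus musculus) for antiproliferative activity; on this read-out lower numbers stand for stronger inhibition of growth and higher numbers for weaker inhibition of growth:
- Compound 1 `Cc1ccc(NC(=O)c2cccc(C(F)(F)F)c2)cc1OC1CCN(C(=O)c2cccnc2)CC1` gives > 10000 nM as a limit
- Compound 2 `Cc1ccc(NC(=O)c2cccc(C(F)(F)F)c2)cc1OC1CCN(C(=O)c2ccno2)CC1` gives > 10000 nM as a limit
- Compound 3 `C=CC(=O)N1CCC(Oc2cc(NC(=O)c3cccc(C(F)(F)F)c3)ccc2C)CC1` gives > 10000 nM as a limit

Compound 1 gives > 10000 nM as a limit and not a number. Compound 1 shares the limit of > 10000 nM in this assay, at which 3 of the 3 values shown sit, and cannot be ranked against the other two compounds.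

Compound 4 `O=C(Nc1cccc(OC2CCN(C(=O)c3cccnc3)CC2)c1)c1cccc(C(F)(F)F)c1` differs from compound 1 by hydrogen in place of methyl on an aromatic carbon in a single change, hydrogen in place of methyl on an aromatic carbon.

Within the data shown here, no measured step touches this methyl. The three measured steps change the group on the carbonyl carbon and give a step that the two limits leave unreadable from compound 1 to compound 2 and a step that the two limits leave unreadable from compound 1 to compound 3 and a step that the two limits leave unreadable from compound 2 to compound 3 with no size to carry over.

Compound 1 gives > 10000 nM as its limit and offers no readable step, so no direction is expected in this assay and no step beyond the scatter. The expected step is a number no higher from compound 1 to compound 4 (the limit leaves the size open) and it is expected to stand only as a limit. For compound 4 the estimate is 10000 nM with an expected range from 4000 nM to 20000 nM as the working guess.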

Compound 4, concentration for 50% growth inhibition: > 10000 nM
Compound 4: a limit, no number; the forecaster's own chance of this, stated with the estimate: 85%; the middle value sits exactly at the limit.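

In this assay compound 4 gives > 10000 nM, which is a limit and not a number. No step can be read between compound 1 and compound 4, and the same holds across the whole set: the limit of > 10000 nM in this assay, at which 4 of the 4 values shown sit.

The compounds shown leave open whether swapping the methyl for hydrogen, or changing the group on the carbonyl carbon, affects growth inhibition at all.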